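The source may report more compounds than this note shows. Statements on the series, on what has been measured and on what is new or still open speak of the compounds shown alone.

Compound 1, `COc1cc(-c2nnc(SCc3ccccc3)n2-c2ccc(N(C)C)cc2)cc(OC)c1OC`, opens the set. In a functional assay on HCT-116 cells (Homo sapiens) for inhibition, read by MTT assay, with a stated time of 48 h (on this read-out higher numbers stand for weaker inhibition and lower numbers for stronger inhibition), compound 1 gives 54000 nM. Compound 2, `COc1ccc(CSc2nnc(-c3cc(OC)c(OC)c(OC)c3)n2-c2ccc(N(C)C)cc2)cc1`, is built on the same core and differs from compound 1 in one place: methoxy in place of hydrogen on an aromatic carbon. In this assay compound 2 gives 1150 nM, and the step reads a 47-fold lower number from compound 1 to compound 2 (1.67 log units; beyond the scatter). Compound 3, `COc1cc(-c2nnc(SCC(=O)c3ccccc3)n2-c2ccc(N(C)C)cc2)cc(OC)c1OC`, carries a changed core; the difference between the core of compound 1 and that of compound 3 is benzoyl in place of phenyl on a saturated chain carbon bound to a sulfur. In this assay compound 3 gives 42500 nM, so the step is a 1.3-fold lower number from compound 1 to compound 3 (0.10 log units; within the scatter), and against compound 2 the step is a 37-fold higher number from compound 2 to compound 3 (1.57 log units; beyond the scatter).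

Compound 4, `COc1ccc(C(=O)CSc2nnc(-c3cc(OC)c(OC)c(OC)c3)n2-c2ccc(N(C)C)cc2)cc1`, has not been measured. It stands to compound 3 as compound 2 stands to compound 1: the change is methoxy in place of hydrogen on an aromatic carbon, and the surroundings of the place are described in the same words in both pairs, so it is taken to be the same change on a different core. For the measured compounds named here, the only guide to its size is the single pair already seen, where the change gave a 47-fold lower number from compound 1 to compound 2 (1.67 log units; beyond the scatter). On that basis the step from compound 3 to compound 4 in this assay is expected to be a 28-fold lower number from compound 3 to compound 4 (1.45 log units; beyond the scatter), with the range kept broad because the precedent comes from one pair. Compound 4 is therefore estimated at 1500 nM, expected to fall between 400 nM and 8000 nM.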

Compound 4, half-maximal inhibitory concentration: > 60000 nM
Compound 4 gave a limit, no number; the forecaster's own chance of this, stated with the estimate: 0%; middle value at least 40-fold (1.60 log units) away from the limit.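

Compound 4 gives > 60000 nM in this assay, and this is a limit of the assay, not a number. For the compounds shown here, the methoxy change that gave a 47-fold lower number from compound 1 to compound 2 (1.67 log units; beyond the scatter) did not carry over to the core of compound 3, where the step is an at least 1.4-fold higher number from compound 3 to compound 4 (0.14 log units; that floor lies within the scatter), and the two further steps, an at least 52-fold higher number from compound 2 to compound 4 (1.71 log units; beyond the scatter) and an at least 1.1-fold higher number from compound 1 to compound 4 (0.04 log units; that floor lies within the scatter), are also floors, so the change cannot be treated as independent of the core: the same change on two cores in this assay, a 47-fold lower number (1.67 log units; beyond the scatter) from compound 1 to compound 2 and an at least 1.4-fold higher number (0.14 log units; that floor lies within the scatter) from compound 3 to compound 4, at least 66-fold (1.82 log units) apart, beyond the scatter of two such steps This shows that the gain seen on the first core cannot be assumed on the second, but it does not give the true size of the step from compound 3 to compound 4, it does not establish any rule for other cores, since it rests on only two pairs, and it does not explain the difference.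

The compounds shown leave open how other groups on the same aromatic carbon, such as a chlorine or a hydroxyl in place of methoxy, would behave on each of the two cores. They also leave open whether a longer chain on the sulfur, or an amide in place of the carbonyl, would restore the gain seen with methoxy on the first core.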